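The source may hold more compounds than are shown below. What is called first, only, known or untested is meant among the compounds shown, and "the series" means these compounds.

Measured so far:
- compound 1, `Cc1ccc2c(c1)CCN2S(=O)(=O)c1ccc(-c2cnc(C3CC3)o2)cc1`, gives 74.7% in an ADME assay on HEK-293T cells (Homo sapiens) for inhibition, read by MTT assay, tested at 10 uM; on this read-out higher numbers stand for more inhibition at the one concentration tested (going by the name of the read-out) and lower numbers for less inhibition
- compound 2, `O=S(=O)(c1ccc(-c2nnc(C3CC3)o2)cc1)N1CCc2ccccc21`, gives -13.8% in this assay

Compound 2 stands at the bottom of these two numbers; compound 1 sits far above it, with a gap that is well beyond the usual scatter of this assay. The unmeasured compound 3, `O=S(=O)(c1ccc(-c2cnc(C3CC3)s2)cc1)N1CCc2ccccc21`, keeps the whole of compound 2 except for one change: 2-cyclopropyl-1,3-thiazol-5-yl in place of 5-cyclopropyl-1,3,4-oxadiazol-2-yl on an aromatic carbon. Going by the values given here, no measured pair shows exactly this swap, so the direction is not fixed by the data. The two values on hand do show that changes in this part of the molecule, together with the indoline substituent, can move the read-out from almost nothing to strong inhibition. A step from compound 2 to compound 3 of moderate size toward more inhibition is expected, a number 48.8 percentage points higher from compound 2 to compound 3 (beyond the scatter), with wide uncertainty. Compound 3 is estimated at 35%, within a range from -5% to 75%.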

Compound 3, a percentage reported as inhibition, at one concentration (the size of the read-out at that concentration, not a potency): -15.4%
Compound 3: the middle estimate sits 50.4 percentage points above what was measured; measured number outside the range, below it.
By their numbers in this assay, from the lowest: compounds 3 and 2 (each within the scatter of the next); then compound 1.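

In this assay, 2-cyclopropyl-1,3-thiazol-5-yl in place of 5-cyclopropyl-1,3,4-oxadiazol-2-yl gives a number 1.6 percentage points lower from compound 2 to compound 3 (within the scatter). At this place, on an aromatic carbon para to a large group, a five-membered aromatic ring with 2 hetero atoms and 2 hydrogen-bond acceptors therefore reads the same as one with 3 hetero atoms and 3 hydrogen-bond acceptors, at least with this unsubstituted partner on the sulfonyl side. The data offer no measured explanation for this lack of change.

On these data alone, compound 2 and compound 3 each differ from compound 1 in more than one place, so it remains open which difference goes with the value of compound 1, 74.7%. Also open, as far as these compounds go, is whether an amine or a longer chain in place of the cyclopropyl would move this read-out.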